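A few compounds are considered here, and "the series" means these few. Any claim that something is new, unique, unknown or untested is made for them only; others in the source may bear on it.

Series notes. Of the compounds shown here, three have so far been measured in an ADME assay on microsomes from liver (Homo sapiens), read by LC-MS, using NADPH, with a stated time of 30 min, tested at 1 uM; on this read-out higher numbers stand for a more stable compound and lower numbers for a less stable compound. Compound 1 `Cc1c(F)ccc2cc([C@H](C)Nc3ncnc(N)c3C#N)c(-c3ccccc3)c(=O)n12` gives 89%. Compound 2 `C[C@H](Nc1ncnc2[nH]cnc12)c1cc2ccc(F)cn2c(=O)c1-c1ccccc1` gives 98%. Compound 3 `Cc1cccc(-c2c([C@H](C)Nc3nc(N)nc(N)c3C#N)cc3ccc(F)cn3c2=O)c1` gives 89%. On these numbers compound 3 stands level with compound 1 at the digits shown, and its gap to compound 2 falls within the usual scatter of repeated measurements, so this assay does not separate the three compounds; all of them sit close to the top of the scale.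

Compound 4 `Cc1cc(F)cc(-c2c([C@H](C)Nc3nc(N)nc(N)c3C#N)cc3ccc(F)cn3c2=O)c1` has not yet been measured. It differs from compound 3 in one place: fluoro in place of hydrogen on an aromatic carbon. Among the compounds with values here, no measured pair in the set isolates this change, so there is no step to lean on. Because compound 3 already gives 89%, there is little room upward, and the added fluorine is not expected to move the read-out beyond the scatter in either direction. The step from compound 3 to compound 4 in this assay is therefore estimated at a number 1 percentage points higher from compound 3 to compound 4 (within the scatter), essentially none. Compound 4 in this assay is expected to give 90%, with a range from 78% to 98%.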

Compound 4, percent of the compound remaining: 80%
Compound 4: the middle estimate sits 10 percentage points above what was measured; low and high end bracket the measured number.
By their numbers in this assay, from the lowest: compounds 4, 1, 3 and 2 (each within the scatter of the next, the first and the last beyond it).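

In this assay, within the data shown here, the change from 3-methylphenyl to 3-fluoro-5-methylphenyl is the first that can be read on its own, and it gives a number 9 percentage points lower from compound 3 to compound 4 (within the scatter) for fluoro in place of hydrogen on an aromatic carbon. This position on the six-membered aromatic ring therefore takes a fluoro without a difference that this read-out can resolve, although this rests on a single pair of compounds and holds only for the core and side chain they share. No measurement shown here bears on the reason for the size of this step.

From the compounds shown here alone, it remains open whether a larger or differently built group at the same aromatic carbon, such as chloro, methoxy or an amine, would also stay within the scatter or would produce a step beyond it. Going by these compounds, it is equally open whether fluoro in place of hydrogen would give a step of similar size on the phenyl ring of compound 1 or compound 2, where the rest of the molecule differs.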